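From compound 1 to a trifluoromethyl carbonyl

This account rests on a few compounds, and the source may have more. Where it says the series, first, only, none or still open, it means among the compounds named here.

Measured in a functional assay on U-937 cells (Homo sapiens) for antiproliferative activity, read by MTT assay, with a stated time of 72 h; on this read-out higher numbers stand for weaker inhibition and lower numbers for stronger inhibition:
compound 1 `Nc1ccccc1NC(=O)CCCCCCc1nc(-c2ccccc2)no1`: 730 nM
compound 2 `Nc1ccccc1NC(=O)CCCCCCc1nc(-c2ccc(Cl)cc2)no1`: 4360 nM

Of the two, compound 1 gives the lower number, 730 nM. Compound 3 `O=C(CCCCCCc1nc(-c2ccccc2)no1)C(F)(F)F` keeps the core of compound 1 but has trifluoromethyl in place of (2-aminophenyl)amino on a carbonyl carbon. For the measured compounds named here, the only measured step is a 6.0-fold higher number from compound 1 to compound 2 (0.78 log units; beyond the scatter), for chloro in place of hydrogen on an aromatic carbon. It concerns a different part of the structure, so it offers only a scale. A step of similar or larger size toward a higher number is therefore expected in this assay. The expected step is a 6.8-fold higher number from compound 1 to compound 3 (0.84 log units; beyond the scatter). Compound 3 is estimated at 5000 nM, with an expected range of 1000 nM to 30000 nM.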

Compound 3, half-maximal inhibitory concentration: 410 nM
The estimate for compound 3 lay 12-fold (1.09 log units) above the measured number, outside the stated range (below it).
By their numbers in this assay, from the lowest: compounds 3 and 1 (each within the scatter of the next); then compound 2.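

In this assay, trifluoromethyl in place of (2-aminophenyl)amino on a carbonyl carbon gives a 1.8-fold lower number from compound 1 to compound 3 (0.25 log units; within the scatter), so the two compounds cannot be told apart. At this position, then, the number holds without the six-membered aromatic ring and the hydrogen-bond donors of (2-aminophenyl)amino. No available evidence bears on this result. Going by these compounds, it remains open whether a carboxylic acid or a hydroxamic acid on the same carbonyl carbon would stay at this level. Also open, on these data alone, is how a longer chain, or chloro on the aromatic carbon of compound 3, would change the number.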